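This account rests on a few compounds, and the source may have more. Where it says the series, first, only, none or still open, it means among the compounds named here.

Measured so far:
compound 1 `CC1=C(C(=O)OC(C)C)C(c2ccccc2)N/C(=N/C#N)N1` — 32%
compound 2 `CC1=C(C(=O)OC(C)C)C(C2CCCC2)NC(=O)N1` — 3%

In an assay on HEK293 cells for displacement of a labelled ligand from adenosine receptor A2b (Homo sapiens), with a stated time of 30 min, tested at 1 uM (on this read-out higher numbers stand for more inhibition at the one concentration tested (going by the name of the read-out) and lower numbers for less inhibition), compound 1 gives 32%, the higher of the two numbers. Compound 2 gives 3%, a value that lies beyond the scatter below it. Compound 3 `CCOC(=O)C1=C(C)N/C(=N\C#N)NC1c1ccccc1` differs from compound 1 in one place: hydrogen in place of methyl on a saturated chain carbon bound to an oxygen next to a carbonyl group and a saturated chain carbon. No measured pair among these compounds shows a change of this kind, so the expectation rests on compound 1 alone. The change is expected to move this assay little, with no step beyond the scatter in either direction. Compound 3 is therefore expected to give 28%, between 10% and 45%. For compound 3 this means an expected step of a number 4 percentage points lower from compound 1 to compound 3 (within the scatter).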

Compound 3, a percentage reported as inhibition, at one concentration (the size of the read-out at that concentration, not a potency): 25%
Beside the measured number, compound 3's estimate is 3 percentage points above it, and the stated range covers the measured number.
By their numbers in this assay, from the lowest: compound 2; then compounds 3 and 1 (each within the scatter of the next).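

In this assay, for the compounds shown here, the change from isopropoxycarbonyl to ethoxycarbonyl gives a number 7 percentage points lower from compound 1 to compound 3 (within the scatter) and is the first pair that isolates a single change on this core. At this place, a saturated chain carbon bound to an oxygen next to a carbonyl group and a saturated chain carbon, the read-out does not separate the isopropoxy from the ethoxy ester. No evidence on hand bears on this result. The compounds shown leave open how a longer chain such as butoxy would read at this ester, and how a carboxylic acid or an amide in its place would read.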